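The source may hold more compounds than are shown below. What is called first, only, known or untested is meant among the compounds shown, and "the series" means these compounds.

Series notes. The shared core carries a benzyl group on a ring amine; three members are in hand. Compound 1 `COc1ccc2[nH]c3c(c2c1)CCNC31CCN(Cc2ccc(Cl)cc2Cl)CC1` gives 1800 nM in an assay on FRT cells for positive allosteric modulation of Cystic fibrosis transmembrane conductance regulator variant N1303K (Homo sapiens), in the presence of a further agent that is not named here; on this read-out lower numbers stand for an effect already at smaller amounts and higher numbers for an effect only at larger amounts of compound. Compound 2 `COc1ccc2[nH]c3c(c2c1)CCNC31CCN(Cc2ccccc2Cl)CC1` gives 2200 nM in this assay, a change of a 1.2-fold higher number from compound 1 to compound 2 (0.09 log units; within the scatter). Compound 3 `COc1ccc2[nH]c3c(c2c1)CCNC31CCN(Cc2ccc(F)c(Cl)c2F)CC1` gives 4500 nM in this assay, with steps of a 2.5-fold higher number from compound 1 to compound 3 (0.40 log units; beyond the scatter) and a 2.0-fold higher number from compound 2 to compound 3 (0.31 log units; beyond the scatter).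

The move from compound 1 to compound 2 is hydrogen in place of chloro on an aromatic carbon. Compound 4 `COc1ccc2[nH]c3c(c2c1)CCNC31CCN(Cc2ccc(F)cc2F)CC1` is not yet measured; it differs from compound 3 by hydrogen in place of chloro on an aromatic carbon, the same kind of change, though the two cores differ by 3-chloro-2,4-difluorophenyl in place of 2,4-dichlorophenyl on a saturated chain carbon bound to an amine nitrogen in a ring and the place differs: meta to a chloro group and para to a large group in the first pair, ortho to two fluoro groups and meta to a large group in the second.

Because a 1.2-fold higher number from compound 1 to compound 2 (0.09 log units; within the scatter) lay within the scatter, the step from compound 3 to compound 4 is expected to be a 1.1-fold higher number from compound 3 to compound 4 (0.05 log units; within the scatter). Compound 4 is estimated at 5000 nM, between 2500 nM and 10000 nM.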

Compound 4, half-maximal effective concentration: 2000 nM
Compound 4: middle estimate off by 2.5-fold (0.40 log units), on the high side, outside the stated range (below it).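

Hydrogen in place of chloro on an aromatic carbon does not carry over as a fixed step between these two cores in this assay: the same change on two cores in this assay, a 1.2-fold higher number (0.09 log units; within the scatter) from compound 1 to compound 2 and a 2.3-fold lower number (0.35 log units; beyond the scatter) from compound 3 to compound 4, 2.8-fold (0.44 log units) apart, beyond the scatter of two such steps. On the core of compound 3 the change gives a 2.3-fold lower number from compound 3 to compound 4 (0.35 log units; beyond the scatter), and compound 4 then stands level with the other two members, with a 1.1-fold lower number from compound 2 to compound 4 (0.04 log units; within the scatter) and a 1.1-fold higher number from compound 1 to compound 4 (0.05 log units; within the scatter). The chloro group also leaves a different place in each pair, so these two pairs do not separate the effect of the core from that of the place, and they set no rule for other cores.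

Still open, on these data alone, is how a benzyl ring carrying a methoxy or trifluoromethyl group would behave. As far as these compounds go, a longer chain in place of the benzyl link, or an amine or carboxylic acid on the ring, also remains open.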